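A few compounds are considered here, and "the series" means these few. Any claim that something is new, unique, unknown or untested is made for them only; others in the source may bear on it.

Measured in a functional assay on DU-145 cells (Homo sapiens) for antiproliferative activity, read by MTT assay, with a stated time of 72 h; on this read-out lower numbers stand for stronger inhibition and higher numbers for weaker inhibition:
- compound 1 `COc1cc2c(Nc3ccc(C#N)cc3)ncnc2cc1OCCCN1CCCCC1`: 24400 nM
- compound 2 `COc1cc2c(Nc3ccc(C#N)cc3)ncnc2cc1OCCCN1CCC(c2ccccc2)CC1`: 6790 nM

Of these two, compound 2 has the lower number in this assay. Compound 3 `COc1cc2c(Nc3ccc(C#N)cc3)ncnc2cc1OCCCN1CCC(N(C)C)CC1` has dimethylamino in place of phenyl on a saturated ring carbon. For the measured compounds named here, the one measured step that bears on this change is the modest 3.6-fold lower number from compound 1 to compound 2 (0.56 log units; beyond the scatter), which came with phenyl in place of hydrogen at that same carbon. Going by the values given here, no measured compound carries dimethylamino, so with phenyl leaving, a modest move towards a higher number is expected: a 2.2-fold higher number from compound 2 to compound 3 (0.34 log units; beyond the scatter). For compound 3 the estimated value is 15000 nM, with an expected range of 5000 nM to 45000 nM.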

Compound 3, half-maximal inhibitory concentration: 28300 nM
For compound 3 the middle estimate is 1.9-fold (0.28 log units) below the measured one; measured number inside the range.
By their numbers in this assay, from the lowest: compound 2; then compounds 1 and 3 (each within the scatter of the next).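

In this assay, dimethylamino at this saturated ring carbon does not keep what phenyl gave: the change brings a 4.2-fold higher number from compound 2 to compound 3 (0.62 log units; beyond the scatter), so the gain seen with phenyl does not extend to this group. Set against hydrogen at the same carbon, dimethylamino gives a 1.2-fold higher number from compound 1 to compound 3 (0.06 log units; within the scatter), leaving compound 1 and compound 3 indistinguishable and phenyl alone among these three groups with a lower number. No evidence is available on what lies behind this difference. As far as these compounds go, whether a cyclohexyl group or a carboxylic acid at this carbon would side with phenyl or with dimethylamino stays open.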